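Amide aryl replacement and cell tolerance in the series

The source may hold more compounds than are shown below. What is called first, only, known or untested is meant among the compounds shown, and "the series" means these compounds.

Readings are from an ADME assay on MT4 cells (Homo sapiens) for cytotoxicity, read by MTT assay, with a stated time of 5 days; a lower number here means that less compound is tolerated, a higher number that more compound is tolerated.

Compound 1 `Cc1cccc(C)c1NC(=O)CSc1snnc1-c1ccc(Br)cc1Br`: >= 198000 nM, a limit of the assay.
Compound 2 `O=C(CSc1snnc1-c1ccc(Br)cc1Br)Nc1cccnc1Cl`: > 240000 nM, also a limit of the assay.
Compound 3 `O=C(CSc1snnc1-c1ccc(Br)cc1Br)Nc1ccccc1`: 24800 nM.

Within the data shown here, compound 3 carries the only numeric reading; the other two entries sit at limits. The change 1,3-thiazol-2-yl in place of phenyl on an amide-type nitrogen gives compound 4 `O=C(CSc1snnc1-c1ccc(Br)cc1Br)Nc1nccs1`. Among the measured compounds shown here, no measured step exchanges phenyl for a heteroaryl directly. The nearest steps are an at least 7.9-fold lower number from compound 1 to compound 3 (0.90 log units; beyond the scatter) and an at least 9.6-fold lower number from compound 2 to compound 3 (0.98 log units; beyond the scatter), both moving to a lower number in this assay when phenyl entered. Read in reverse, replacing phenyl with 1,3-thiazol-2-yl is expected to raise the number by a modest step, a 2.4-fold higher number from compound 3 to compound 4 (0.38 log units; beyond the scatter). Compound 4 is therefore estimated at 60000 nM, within 20000 nM to 200000 nM.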

Compound 4, half-maximal cytotoxic concentration: 87800 nM
The estimate for compound 4 lay 1.5-fold (0.17 log units) below the measured number; the range from low to high includes it.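

In this assay, the direct step shows that a heteroaryl on the amide-type nitrogen can give a higher number than phenyl: a 3.5-fold higher number from compound 3 to compound 4 (0.55 log units; beyond the scatter). Compound 4 still falls short of the other two aryl replacements, with an at least 2.7-fold lower number from compound 2 to compound 4 (0.43 log units; beyond the scatter) and an at least 2.2-fold lower number from compound 1 to compound 4 (0.35 log units; beyond the scatter). The entries for compound 1 and compound 2 are limits of the assay, so these two steps have no upper bound, and nothing shown gives a cause for any of the three.

As far as these compounds go, whether the rise is specific to 1,3-thiazol-2-yl stays open. A 1,3-oxazol-2-yl or pyridin-2-yl at the same place would test this.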